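Side-chain amine exchange on the shared core

This account rests on a few compounds, and the source may have more. Where it says the series, first, only, none or still open, it means among the compounds named here.

Measured compounds:
- compound 1 `CC/C=C/C(=O)Nc1cc2c(N3CCCc4ccccc43)ncnc2cc1OC`: 2870 nM
- compound 2 `CCN(CC)C/C=C/C(=O)Nc1cc2c(N3CCCc4ccccc43)ncnc2cc1OC`: 5310 nM

In a functional assay on MCF7 cells (Homo sapiens) for antiproliferative activity, read by MTT assay, with a stated time of 72 h (on this read-out higher numbers stand for weaker inhibition and lower numbers for stronger inhibition), compound 2 gives 5310 nM and compound 1 gives 2870 nM; the two numbers cannot be separated, since a 1.9-fold higher number from compound 1 to compound 2 (0.27 log units; within the scatter).

Compound 3 `COc1cc2ncnc(N3CCCc4ccccc43)c2cc1NC(=O)/C=C/CN1CCN(C)CC1` is not yet measured. It differs from compound 2 by 4-methylpiperazin-1-yl in place of diethylamino on a saturated chain carbon bound to a double-bonded chain carbon. For the measured compounds named here, the only step that touches this part of the molecule is the one from compound 1 to compound 2, in which the amine was introduced at the same place, and a 1.9-fold higher number from compound 1 to compound 2 (0.27 log units; within the scatter). That exchange left the read-out unchanged within the scatter, so a second exchange of one amine for another at the same place is expected to do the same: no step beyond the scatter in either direction is anticipated.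

For compound 3 the estimate is therefore 4800 nM (range 2000 nM to 12000 nM), meaning an expected 1.1-fold lower number from compound 2 to compound 3 (0.04 log units; within the scatter).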

Compound 3, half-maximal inhibitory concentration: 8560 nM
Estimate against measurement, compound 3: 1.8-fold (0.25 log units) below, and the stated range covers the measured number.
By their numbers in this assay, from the lowest: compounds 1, 2 and 3 (each within the scatter of the next, the first and the last beyond it).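

In this assay the exchange of diethylamino for 4-methylpiperazin-1-yl gives a 1.6-fold higher number from compound 2 to compound 3 (0.21 log units; within the scatter) and so does not separate these two amines at this place on the chain. Set against the methyl of compound 1, the same group gives a 3.0-fold higher number from compound 1 to compound 3 (0.47 log units; beyond the scatter) as the first step at this position beyond the scatter, a modest one towards weaker inhibition, while compound 2 stays within the scatter of both neighbours and so does not carry that separation itself. Nothing available bears on the reason for this result.

Open, going by these compounds, is how a morpholin-4-yl or a dimethylamino group would read at this same place. Also open, on these data alone, is whether a longer chain carrying 4-methylpiperazin-1-yl would stay within the scatter of compound 3.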